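A Smaller Amide Tail and Expected Lung Exposure

The source may report more compounds than this note shows. Statements on the series, on what has been measured and on what is new or still open speak of the compounds shown alone.

Within the data shown here, compound 2 `NCc1cc(Oc2cccc(C(=O)N3CC[C@@H](N)C3)c2)nc(C(F)(F)F)c1` holds the only number in an ADME assay on the whole organism (lung, Mus musculus) for pharmacokinetics, read by LC-MS, at a dose of 30 mg/kg by the oral route; a lower number here means less compound in the circulation, a higher number more compound in the circulation at the dose given: compound 2 gives 1230 nM. In this assay compound 1 `NCc1cc(Oc2cccc(Oc3ccccc3)c2)nc(C(F)(F)F)c1` gives "not determined" (no result reported). Compound 3 `CONC(=O)c1cccc(Oc2cc(CN)cc(C(F)(F)F)n2)c1` has not yet been measured. The change from compound 2 to compound 3 is methoxyamino in place of 3-aminopyrrolidin-1-yl on a carbonyl carbon. Among the measured compounds shown here, with a single number, no step between measured compounds exists to guide the expectation, so the step is expected to be modest and within the scatter in either direction, as a 1.0-fold lower number from compound 2 to compound 3 (0.01 log units; within the scatter) shows. Compound 3 is therefore estimated to give 1200 nM, with a range from 400 nM to 3500 nM.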

Compound 3, maximal plasma concentration: 8780 nM
For compound 3 the middle estimate is 7.3-fold (0.86 log units) below the measured one; the whole stated range lies below it.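

In this assay this position responds strongly: methoxyamino in place of 3-aminopyrrolidin-1-yl on a carbonyl carbon gives a 7.1-fold higher number from compound 2 to compound 3 (0.85 log units; beyond the scatter) and so shows that the group on this carbonyl can shift the number well past the scatter. This is a single step, so it sets no trend. No available evidence explains the rise.

The compounds shown leave open whether the ring, the ring's amine or the oxygen of methoxyamino matters most. A plain methylamino group or an open-chain aminoethylamino group on the same carbonyl would help separate these.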